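The source may hold more compounds than are shown below. What is called first, only, known or untested is meant among the compounds shown, and "the series" means these compounds.

The measurements come from an ADME assay on HEK293 cells (Homo sapiens) for cytotoxicity, read by resazurin assay, with a stated time of 48 h (on this read-out higher numbers stand for lower toxicity in this test and lower numbers for higher toxicity in this test), which here was run on three compounds:

compound 1 `Cc1ccccc1S(=O)(=O)Nc1ccc2oc(-c3ccccc3)nc2c1` gives 57000 nM
compound 2 `COc1ccc(Cl)cc1S(=O)(=O)Nc1ccc(-c2nc3ccccc3o2)cc1` gives 75000 nM
compound 3 `CCc1ccc(S(=O)(=O)Nc2ccc(-c3nc4ccccc4o3)cc2)cc1` gives 82000 nM

None of these three numbers stands apart from the others: the gaps from compound 1 to compound 2 and from compound 1 to compound 3 both fall within the scatter of repeated measurements, so compound 1 cannot be told apart from either of them on this read-out.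

Compound 4 `C=Cc1ccc(S(=O)(=O)Nc2ccc3oc(-c4ccccc4)nc3c2)cc1` has not yet been measured in this assay. It differs from compound 1 in one place, (4-vinylphenyl in place of 2-methylphenyl on a sulfonyl sulfur).

For the measured compounds named here, one measured step touches the same position, a swap of the aryl group on the sulfonyl sulfur: a 1.1-fold higher number from compound 2 to compound 3 (0.04 log units; within the scatter). That change of the aryl group left the read-out unmoved. Going by the values given here, with only this step to go on, the swap from 2-methylphenyl to 4-vinylphenyl on the sulfonyl sulfur is expected to give a step of a 1.1-fold higher number from compound 1 to compound 4 (0.04 log units; within the scatter), that is, nothing beyond the scatter. Compound 4 is therefore estimated at 62000 nM, with a range from 30000 nM to 125000 nM.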

Compound 4, half-maximal cytotoxic concentration: 53000 nM
The estimate for compound 4 lay 1.2-fold (0.07 log units) above the measured number, and the stated range covers the measured number.
By their numbers in this assay, from the lowest: compounds 4, 1, 2 and 3 (each within the scatter of the next).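

Replacing 2-methylphenyl with 4-vinylphenyl on the sulfonyl sulfur gives a 1.1-fold lower number from compound 1 to compound 4 (0.03 log units; within the scatter) in this assay and does not move the read-out beyond the scatter. For the compounds shown here, the only earlier step at this position, a 1.1-fold higher number from compound 2 to compound 3 (0.04 log units; within the scatter) on the other core, was also within the scatter, so this result extends that observation to the core of compound 1 and to an incoming group with a double bond outside the aromatic ring. Nothing shown here explains why the read-out stays within the scatter.

All four compounds carry an aryl group on the sulfonyl sulfur, and none of these aryl groups bears an amine or a carboxylic acid. Going by these compounds, it therefore remains open whether either of those groups, or a plain alkyl chain in place of the aryl group, would also leave the read-out within the scatter.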